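From a Dimethylamino Chain to a Piperazine

A few compounds are considered here, and "the series" means these few. Any claim that something is new, unique, unknown or untested is made for them only; others in the source may bear on it.

Among the compounds with values here, in a toxicity assay on HEK-293T cells (Homo sapiens) for cytotoxicity, read by MTT assay, with a stated time of 72 h (on this read-out higher numbers stand for weaker inhibition and lower numbers for stronger inhibition), compound 1 `CN(C)CCCCCn1c2c(c3ccccc31)C(=O)c1c[n+]([O-])c3ccccc3c1C2=O` gives 70 nM, the lowest of the two numbers so far, while compound 2 `CC1(C)OCC(Cn2cc(Cn3c4c(c5ccccc53)C(=O)c3c[n+]([O-])c5ccccc5c3C4=O)nn2)O1` gives 5510 nM. Compound 3 `O=C1c2c[n+]([O-])c3ccccc3c2C(=O)c2c1c1ccccc1n2CCCCN1CCNCC1` keeps the core of compound 1 but carries piperazin-1-yl in place of (dimethylamino)methyl on a saturated chain carbon, four bonds along the chain from an aromatic nitrogen. Within the data shown here, no pair of measured compounds shows this change on its own, so the estimate is uncertain. The expected step in this assay is a modest weakening, a 2.9-fold higher number from compound 1 to compound 3 (0.46 log units; beyond the scatter). The estimated value for compound 3 is 200 nM, with a range of 50 nM to 900 nM.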

Compound 3, half-maximal inhibitory concentration: 760 nM
For compound 3 the middle estimate is 3.8-fold (0.58 log units) below the measured one; the range from low to high includes it.
By their numbers in this assay, from the lowest: compound 1; then compound 3; then compound 2.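

Replacing (dimethylamino)methyl with piperazin-1-yl at this place on the chain is far from a neutral swap: in this assay it gives an 11-fold higher number from compound 1 to compound 3 (1.04 log units; beyond the scatter). The group at the far end of the chain therefore clearly affects this read-out, and the larger ring-bearing group goes with the weaker inhibition in this one pair. No measurement here explains the step.

Going by these compounds, it remains open how 4-methylpiperazin-1-yl or morpholin-4-yl would read at the same place. On these data alone, whether a longer chain carrying piperazin-1-yl would move the number back towards that of compound 1 is also open.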